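This account rests on a few compounds, and the source may have more. Where it says the series, first, only, none or still open, it means among the compounds named here.

Measured compounds in a functional assay on CCRF-CEM cells (Homo sapiens) for cytotoxicity, read by cell counting, with a stated time of 3 days; on this read-out higher numbers stand for weaker inhibition and lower numbers for stronger inhibition:
compound 1 `C=C(Br)C(=O)Nc1ccc(/C=C2\SC(=O)N(Cc3ccc(C)cc3)C2=O)cc1`, 3700 nM
compound 2 `C=C(Br)C(=O)Nc1ccc(/C=C2\SC(=O)N(Cc3ccccc3)C2=O)cc1`, 2300 nM
compound 3 `C=C(Br)C(=O)Nc1ccc(/C=C2\SC(=O)N(Cc3ccc(F)cc3)C2=O)cc1`, 2400 nM

Compound 3 stands at the second highest of the three numbers. Its nearest neighbour is compound 2, with a 1.0-fold higher number from compound 2 to compound 3 (0.02 log units; within the scatter), and compound 1 stands further off, with a 1.5-fold lower number from compound 1 to compound 3 (0.19 log units; within the scatter). All three differ only by the group on an aromatic carbon, and the remaining step, a 1.6-fold lower number from compound 1 to compound 2 (0.21 log units; within the scatter), is likewise within the scatter.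

Compound 4 `C=C(Br)C(=O)Nc1ccc(/C=C2\SC(=O)N(C)C2=O)cc1` carries a different kind of change: hydrogen in place of 4-fluorophenyl on a saturated chain carbon bound to an amide-type nitrogen in a ring. Within the data shown here, no measured step bears on this change: each measured step swaps a group on an aromatic carbon, and none removes the ring. The step in this assay is expected to be a 1.3-fold higher number from compound 3 to compound 4 (0.10 log units; within the scatter), with no direction favoured and a wide range. Compound 4 is estimated at 3000 nM, between 700 nM and 13000 nM.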

Compound 4, half-maximal inhibitory concentration: 360 nM
Estimate against measurement, compound 4: 8.3-fold (0.92 log units) above, and the stated range ends above it.
By their numbers in this assay, from the lowest: compound 4; then compounds 2, 3 and 1 (each within the scatter of the next).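

Replacing the aromatic ring at this saturated chain carbon bound to an amide-type nitrogen in a ring gives clear steps in this assay: a 6.7-fold lower number from compound 3 to compound 4 (0.82 log units; beyond the scatter), a 6.4-fold lower number from compound 2 to compound 4 (0.81 log units; beyond the scatter) and a 10-fold lower number from compound 1 to compound 4 (1.01 log units; beyond the scatter). The aromatic ring is therefore not required for activity in this series, and its removal has an effect that the swaps on its aromatic carbon did not show. Nothing at hand explains this stronger inhibition.

Going by these compounds, it remains open whether an ethyl group or a longer chain would keep this activity. Also open, on these data alone, is whether a saturated ring such as cyclohexylmethyl would track with methyl or with the benzyl groups.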